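Trimming an Ester: From Compound 2 to Compound 3

The source may report more compounds than this note shows. Statements on the series, on what has been measured and on what is new or still open speak of the compounds shown alone.

Two compounds built on the same core have been examined in a functional assay on NIH3T3 cells (Mus musculus) for cytotoxicity, read by sulforhodamine B assay, with a stated time of 48 h; a higher number here means a weaker inhibitor, a lower number a stronger inhibitor. Compound 1, `CCC(C)c1cc(/C=C/C(=O)c2ccc(Cl)cc2)cc2cc(C(C)=O)c(=O)oc12`, was recorded in this assay as "not active" (no number reported), so no number stands beside it. Among the measured compounds shown here, compound 2, `CCOC(=O)c1cc2cc(/C=C/C(=O)c3ccc(Cl)cc3)cc(C(C)CC)c2oc1=O`, gives 38400 nM in this assay, and that is the only number reported so far; compound 2 therefore stands alone, with nothing measured to rank it against.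

Compound 3, `CCC(C)c1cc(/C=C/C(=O)c2ccc(Cl)cc2)cc2cc(C(=O)OC)c(=O)oc12`, has not yet been measured. It differs from compound 2 in one place: hydrogen in place of methyl on a saturated chain carbon bound to an oxygen next to a carbonyl group. In other words, the ethoxycarbonyl group of compound 2 becomes a methoxycarbonyl group in compound 3.

For the measured compounds named here, no step between measured compounds is available to show how such a change has behaved on this core. Given that compound 2 sits at 38400 nM, the step from compound 2 to compound 3 in this assay is expected to be a 1.0-fold higher number from compound 2 to compound 3 (0.02 log units; within the scatter), that is, nothing beyond the usual scatter. Compound 3 is therefore estimated to give about 40000 nM in this assay, within a range of 15000 nM to 120000 nM, with a real chance that, as for compound 1, only a statement of inactivity is returned.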

Compound 3, half-maximal inhibitory concentration: 42400 nM
For compound 3 the middle estimate is 1.1-fold (0.03 log units) below the measured one; measured number inside the range.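

In this assay the change from ethoxycarbonyl to methoxycarbonyl gives a 1.1-fold higher number from compound 2 to compound 3 (0.04 log units; within the scatter) and so leaves the two compounds indistinguishable. Among the compounds shown here, this is the first measured step on the shared core, and it shows that at this place, on a saturated chain carbon bound to an oxygen next to a carbonyl group, hydrogen can stand in place of methyl without a shift that exceeds the ordinary variation between repeated measurements. No supporting measurement is available to explain why the two esters read alike.

A single step cannot show how far this finding extends on the shared core, so a longer chain such as propyl or butyl on the ester oxygen remains an open case. Also open, from the compounds shown here alone, is whether replacing the whole ester with a carboxylic acid or an amide would leave this assay just as unmoved, or would produce a clear change in either direction.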